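Chain-terminal aryl swap on the heteroaryl-thioether amide series

This account rests on a few compounds, and the source may have more. Where it says the series, first, only, none or still open, it means among the compounds named here.

Two compounds of the series carry a number in an assay on cells for inhibition of IL15-IL15 receptor (Homo sapiens), read by AlphaScreen, with stated times of 30 min and 1 h; a higher number here means a weaker inhibitor, a lower number a stronger inhibitor. Compound 1 `CC(C)COc1ccc(NC(=O)CCCCCCCSc2nnc(Cc3nn(C)c(=O)c4ccccc34)n2C)cc1` gives 55000 nM in this assay. Compound 2 `CCCOc1ccc(NC(=O)CCCCCCCSc2nnc(Cc3nn(C)c(=O)c4ccccc34)n2C)cc1` gives 40000 nM, and the change a 1.4-fold lower number from compound 1 to compound 2 (0.14 log units; within the scatter) leaves the two within the scatter of each other, so compound 2 stands alongside compound 1 rather than apart from it. Compound 3 `Cn1c(Cc2nn(C)c(=O)c3ccccc23)nnc1SCCCCCCCC(=O)Nc1ccc(Cl)cc1Cl` is not yet measured. It differs from compound 2 by 2,4-dichlorophenyl in place of 4-propoxyphenyl on an amide-type nitrogen. Among the compounds with values here, no measured step touches the aryl group on the amide-type nitrogen; the one step known, a 1.4-fold lower number from compound 1 to compound 2 (0.14 log units; within the scatter), concerns the alkoxy chain and was itself within the scatter. Nothing in the series therefore points to a shift in this assay beyond the scatter for compound 3, and the expectation is no change at the digits printed from compound 2 to compound 3 (within the scatter). Compound 3 is estimated at 40000 nM, with a range from 15000 nM to 120000 nM in this assay.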

Compound 3, half-maximal inhibitory concentration: 153000 nM
The estimate for compound 3 lay 3.8-fold (0.58 log units) below the measured number, and the stated range ends below it.
By their numbers in this assay, from the lowest: compounds 2 and 1 (each within the scatter of the next); then compound 3.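

Within the data shown here, the aryl group on the amide-type nitrogen is the first place where a change moves the number in this assay beyond the scatter, with 2,4-dichlorophenyl in place of 4-propoxyphenyl giving a 3.8-fold higher number from compound 2 to compound 3 (0.58 log units; beyond the scatter) as the result. The same group in place of 4-(isobutoxy)phenyl gives a 2.8-fold higher number from compound 1 to compound 3 (0.44 log units; beyond the scatter) as its result, so both steps run toward a weaker inhibitor, whichever of the two alkoxy chains leaves. Nothing available explains this shift.

Each step removes the alkoxy chain and brings in two chlorines at once, so the compounds shown do not separate the loss of one from the gain of the other. Unsubstituted phenyl or 4-chlorophenyl could divide the two parts of the change, while a 4-aminophenyl or 4-carboxyphenyl group would test the same position with quite different substituents.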